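A few compounds are considered here, and "the series" means these few. Any claim that something is new, unique, unknown or untested is made for them only; others in the source may bear on it.

Of the compounds shown here, three sharing one core have been measured in an assay on isolated protein for inhibition of Aromatase (Homo sapiens), read by fluorescence, using NADPH, with a stated time of 30 min, tested at 50 uM; on this read-out lower numbers stand for less inhibition and higher numbers for more inhibition at the one concentration tested (going by the name of the read-out). Compound 1 `Nc1ccc(-c2cc3ccccc3[nH]2)cc1` gives 46.2% in this assay. Compound 2 `CO/N=C/c1c(-c2ccccc2)[nH]c2ccccc12` gives 24.7%, the second highest of the three numbers; compound 1 gives a higher number, while compound 3 `C(=N/OCc1ccccc1)\c1c(-c2ccccc2)[nH]c2ccccc12` gives 23.3% and lies nearest to compound 2. Among the measured compounds shown here, the only measured step between compounds differing in a single place is a number 1.4 percentage points lower from compound 2 to compound 3 (within the scatter), phenyl in place of hydrogen on a saturated chain carbon bound to an oxygen.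

Compound 4 `C#Cc1c(-c2ccccc2)[nH]c2ccccc12` has not yet been measured. It differs from compound 2 by a group of 2 heavy atoms (2 carbon; no ring) in place of a group of 4 heavy atoms (2 carbon, 1 nitrogen, 1 oxygen; no ring), on an aromatic carbon, the ethynyl entering on an aromatic carbon of a five-membered aromatic ring with 1 nitrogen, part of a fused system of two rings. For the measured compounds named here, no measured step removes this group; the step from compound 2 to compound 3 only varies the tail of the chain that leaves, and it stayed within the scatter. With nothing bearing directly on the exchange, the expected step of a number 2.3 percentage points higher from compound 2 to compound 4 (within the scatter) is none beyond the scatter. Compound 4 is therefore estimated to give 27% in this assay, with a range from 10% to 48%.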

Compound 4, a percentage reported as inhibition, at one concentration (the size of the read-out at that concentration, not a potency): 88%
Compound 4: the middle estimate sits 61 percentage points below what was measured; measured number outside the range, above it.
By their numbers in this assay, from the lowest: compounds 3 and 2 (each within the scatter of the next); then compound 1; then compound 4.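

In this assay, ethynyl in place of the group of 4 heavy atoms, on an aromatic carbon next to the ring atom that bears a phenyl group, gives a number 63.3 percentage points higher from compound 2 to compound 4 (beyond the scatter). This shows that the read-out responds strongly to what sits at this position, which the earlier step, a number 1.4 percentage points lower from compound 2 to compound 3 (within the scatter), could not show, as it varied only the tail of the chain. Nothing measured here bears on why the step is so large.

The compounds shown leave open whether this gain belongs to ethynyl in particular or would also come with a nitrile, a methyl group or plain hydrogen at this position. Also open, on these data alone, is whether a longer alkyne chain, such as propynyl, would keep it.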